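The source may hold more compounds than are shown below. What is called first, only, known or untested is meant among the compounds shown, and "the series" means these compounds.

Compound 1 `COc1cc(NC(C)CCCNC(=O)/C=C/c2ccccc2)c2ncccc2c1` sets the reference point: in an ADME assay on L6 cells (Rattus norvegicus) for cytotoxicity, read by resazurin assay, with a stated time of 70 h (on this read-out higher numbers stand for weaker inhibition and lower numbers for stronger inhibition), compound 1 gives 7.2 ug/mL. Compound 2 `COc1cc(NC(C)CCCNC(=O)/C(C)=C/c2ccccc2)c2ncccc2c1` reaches only the limit of this assay; compound 2 gives > 100 ug/mL. Compound 3 `COc1ccc(/C=C/C(=O)NCCCC(C)Nc2cc(OC)cc3cccnc23)cc1` likewise reaches only a limit of this assay: compound 3 gives > 100 ug/mL. Thus two of the three values sit at the limit (the limit of > 100 ug/mL in this assay, at which 2 of the 3 values shown sit), so the steps of an at least 13-fold higher number from compound 1 to compound 2 (1.14 log units; beyond the scatter) and an at least 13-fold higher number from compound 1 to compound 3 (1.14 log units; beyond the scatter) are read only as minimum sizes, while a step that the two limits leave unreadable from compound 2 to compound 3. Compound 4 `COc1cc(NC(C)CCCNC(=O)/C=C/c2ccc(OC)c(OC)c2)c2ncccc2c1` differs from compound 3 by methoxy in place of hydrogen on an aromatic carbon. The step that bears on this change is the earlier methoxy addition, an at least 13-fold higher number from compound 1 to compound 3 (1.14 log units; beyond the scatter), which was large and carried compound 3 to the limit. Compound 4 is therefore expected to stay at or near the limit, an expected step of a number no higher from compound 3 to compound 4 (the limit leaves the size open). The estimate for compound 4 is 100 ug/mL, with a range from 40 ug/mL to 300 ug/mL.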

Compound 4, half-maximal inhibitory concentration: > 100 ug/mL
Compound 4 gave a limit, no number; the forecaster's own chance of this, stated with the estimate: 75%; the middle value sits exactly at the limit.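

In this assay compound 4 also gives only a limit, > 100 ug/mL. The 3,4-dimethoxyphenyl group in place of phenyl gives an at least 13-fold higher number from compound 1 to compound 4 (1.14 log units; beyond the scatter), so the large shift first seen with a single methoxy on this ring remains when a second methoxy stands ortho to the first. The steps between compounds at the limit, including the one for this second methoxy, cannot be read, and the series now gathers at one end of the scale: the limit of > 100 ug/mL in this assay, at which 3 of the 4 values shown sit.

Going by these compounds, whether compound 3 and compound 4 truly differ in this assay stays open, as does how far either lies past the limit. Also open, on these data alone, is whether an amine or a hydroxyl group at this position on the ring would give a readable number.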